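Replacing bromo with trifluoromethoxy on compound 2

A few compounds are considered here, and "the series" means these few. Any claim that something is new, unique, unknown or untested is made for them only; others in the source may bear on it.

For the measured compounds named here, in an ADME assay on HeLa cells (Homo sapiens) for cytotoxicity, read by resazurin assay, with a stated time of 2 days (on this read-out higher numbers stand for weaker inhibition and lower numbers for stronger inhibition), compound 2 `Cn1c([N+](=O)[O-])cnc1/C=C/c1ccc(Br)cc1` gives 72400 nM, the only actual number among the three compounds measured. Compound 1 `Cc1ccc(/C=C/c2ncc([N+](=O)[O-])n2C)cc1` reads > 100000 nM, which is a limit of the assay. Compound 3 `Cn1c([N+](=O)[O-])cnc1/C=C/c1ccc(Cl)cc1Cl` reads > 100000 nM, which is also a limit.

Compound 4 `Cn1c([N+](=O)[O-])cnc1/C=C/c1ccc(OC(F)(F)F)cc1` carries trifluoromethoxy in place of bromo on an aromatic carbon, the change being (trifluoromethoxy in place of bromo on an aromatic carbon). Going by the values given here, one measured step bears on this position, the exchange of methyl for bromo, an at least 1.3-fold lower number from compound 1 to compound 2 (0.14 log units; that floor lies within the scatter). Its size is only a floor, and that floor lies within the scatter, so it gives no sign of a large effect at this position. No step beyond the scatter is therefore expected in this assay, and no direction can be assigned with confidence. The estimated step is a 1.1-fold higher number from compound 2 to compound 4 (0.04 log units; within the scatter). Compound 4 may also read only as a limit, given (the limit of > 100000 nM in this assay, at which 2 of the 3 values shown sit). Compound 4 is expected at 80000 nM, with an estimated range from 40000 nM to 140000 nM.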

Compound 4, half-maximal inhibitory concentration: 83200 nM
Estimate against measurement, compound 4: 1.0-fold (0.02 log units) below, and the stated range covers the measured number.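

In this assay, trifluoromethoxy in place of bromo gives a 1.1-fold higher number from compound 2 to compound 4 (0.06 log units; within the scatter), so this position now has a step with an actual number at both ends, where the earlier step rested on a limit. Set against methyl, trifluoromethoxy gives an at least 1.2-fold lower number from compound 1 to compound 4 (0.07 log units; that floor lies within the scatter), which is again only a floor. Compound 4, like compound 2, reads as a number, while the other compounds remain at a limit: the limit of > 100000 nM in this assay, at which 2 of the 4 values shown sit.

From the compounds shown here alone, it remains open whether a different kind of group at this position, such as an amine or a carboxylic acid, would give a step beyond the scatter. Going by these compounds, it also remains open whether a change elsewhere on the shared core would do so.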